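The compounds below may be only part of what the source reports. "The series", "measured", "known", "first", "only" and "open" are said of these compounds alone.

Measured so far in an in vitro ADME assay on microsomes from liver (Homo sapiens) for pharmacokinetics, read by LC-MS, with a stated time of 10 min, tested at 1 uM; on this read-out lower numbers stand for slow clearance and higher numbers for fast clearance:
- compound 1 `CN1C[C@H](C(=O)Nc2ccc(F)cc2)[C@@H](c2ccc(/C=C/C(=O)Nc3ccccc3N)cc2)C1` gives 5 mL/min/kg 
- compound 2 `CN1C[C@H](C(=O)Nc2ccc(C3CC3)cc2)[C@@H](c2ccc(/C=C/C(=O)Nc3ccccc3N)cc2)C1` gives 12 mL/min/kg 
- compound 3 `Cc1ccc(NC(=O)[C@H]2CN(C)C[C@@H]2c2ccc(/C=C/C(=O)Nc3ccccc3N)cc2)cn1` gives 8 mL/min/kg 

Compound 3 holds the second highest of the three numbers, but it lies within the scatter of both others, with a 1.6-fold higher number from compound 1 to compound 3 (0.20 log units; within the scatter) and a 1.5-fold lower number from compound 2 to compound 3 (0.18 log units; within the scatter). Only compound 1 and compound 2 separate, with a 2.4-fold higher number from compound 1 to compound 2 (0.38 log units; beyond the scatter).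

Compound 4 `CN1C[C@H](C(=O)N2CCCCC2)[C@@H](c2ccc(/C=C/C(=O)Nc3ccccc3N)cc2)C1` carries piperidin-1-yl in place of (6-methylpyridin-3-yl)amino on a carbonyl carbon, which is piperidin-1-yl in place of (6-methylpyridin-3-yl)amino on a carbonyl carbon. Among the measured compounds shown here, no measured step makes this kind of change, since all three compounds keep an aromatic ring on the amide-type nitrogen. Those steps therefore bear on it only indirectly, and the largest of them is modest, at a 2.4-fold higher number from compound 1 to compound 2 (0.38 log units; beyond the scatter). A small step is thus expected, within the scatter and tentatively upward. For the measured compounds named here, the estimated change is a 1.3-fold higher number from compound 3 to compound 4 (0.10 log units; within the scatter), with no measured precedent behind its direction. Compound 4 is expected to give 10 mL/min/kg, within an estimated range from 5 mL/min/kg to 22 mL/min/kg, when it is measured.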

Compound 4, clearance: 9 mL/min/kg
Estimate against measurement, compound 4: 1.1-fold (0.05 log units) above, within the range that was stated.
By their numbers in this assay, from the lowest: compounds 1, 3, 4 and 2 (each within the scatter of the next, the first and the last beyond it).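

Compound 4 shows that this carbonyl carbon does not need an aromatic ring on its amide-type nitrogen to stay in the same range of this assay: piperidin-1-yl, with no hydrogen-bond donor, gives a 1.1-fold higher number from compound 3 to compound 4 (0.05 log units; within the scatter). The same change stays within the scatter from the other two anilides, with a 1.3-fold lower number from compound 2 to compound 4 (0.12 log units; within the scatter) and a 1.8-fold higher number from compound 1 to compound 4 (0.26 log units; within the scatter), so compound 4 does not separate from any of them, although compound 1 and compound 2 separate from each other. Nothing measured here explains this result.

The compounds shown leave open whether the aromatic ring or the amide hydrogen matters on its own, since compound 4 changes both at once, and a cyclohexylamino group would keep that hydrogen without the aromatic ring. They also leave open how morpholin-4-yl or an open-chain diethylamino group would read at this carbonyl carbon.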